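The source may hold more compounds than are shown below. What is called first, only, known or untested is meant among the compounds shown, and "the series" means these compounds.

Compound 1 `Cc1ccc(C(=O)N/N=C/c2ccccc2)c(O)c1` gives 578000 nM in an ADME assay on cells (Mus musculus, strain BALB/C) for cytotoxicity, read by MTT assay, with a stated time of 24 h; on this read-out lower numbers stand for higher toxicity in this test and higher numbers for lower toxicity in this test. Compound 2 `Cc1ccc(C(=O)N/N=C/c2ccccc2O)c(O)c1` gives 761000 nM in this assay. Among the measured compounds shown here, the single step available, a 1.3-fold higher number from compound 1 to compound 2 (0.12 log units; within the scatter), lies within the scatter; compound 1 holds the lowest of the two numbers, with compound 2 nearest. Compound 3 `COc1cccc(/C=N/NC(=O)c2ccc(C)cc2O)c1` differs from compound 1 by methoxy in place of hydrogen on an aromatic carbon, meta to a large group. For the measured compounds named here, only that earlier step bears on this change, and it was small, so no step beyond the scatter is expected in this assay. The expected step is a 1.0-fold higher number from compound 1 to compound 3 (0.02 log units; within the scatter). For compound 3 the estimate is 600000 nM, in the range 300000 nM to 1200000 nM.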

Compound 3, half-maximal cytotoxic concentration: 672000 nM
For compound 3 the middle estimate is 1.1-fold (0.05 log units) below the measured one; measured number inside the range.
By their numbers in this assay, from the lowest: compounds 1, 3 and 2 (each within the scatter of the next).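

With methoxy entering where hydrogen leaves, meta to a large group, the result is a 1.2-fold higher number from compound 1 to compound 3 (0.07 log units; within the scatter) in this assay. This extends the picture beyond the earlier hydroxy step: a group with carbon and 0 hydrogen-bond donors also produces no step beyond the scatter on this core. No available evidence explains this result. Still open, from the compounds shown here alone, is whether an amine, a carboxylic acid or a longer alkoxy chain at this position would stay within the scatter of compound 1 . Also open, going by these compounds, is whether any group here produces a step beyond the scatter.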